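Replacing the hydroxy group of compound 2 with hydrogen

A few compounds are considered here, and "the series" means these few. Any claim that something is new, unique, unknown or untested is made for them only; others in the source may bear on it.

In a functional assay on PANC-1 cells (Homo sapiens) for antiproliferative activity, read by fluorescence and resazurin assay, with a stated time of 48 h (on this read-out higher numbers stand for weaker inhibition and lower numbers for stronger inhibition), compound 1 (`O=C(N/N=C/c1ccncc1)c1cc2cc(Br)ccc2oc1=O`) gives 25700 nM and compound 2 (`CCOc1ccc(NC(=O)c2cc3ccc(O)cc3oc2=O)cc1`) gives 14300 nM and these two numbers lie within the usual scatter of each other. Going by the values given here, on the numbers so far, neither compound can be set apart from the other.

Compound 3 (`CCOc1ccc(NC(=O)c2cc3ccccc3oc2=O)cc1`) differs from compound 2 in one place, with hydrogen in place of hydroxy on an aromatic carbon. Among the compounds with values here, no measured pair here shows what this change does, so the data give no direct guide to its size. The closest reference is compound 2 at 14300 nM and no shift beyond the scatter is expected from it. The expected change is a 1.3-fold higher number from compound 2 to compound 3 (0.10 log units; within the scatter) and this estimated step stays within the scatter. In this assay compound 3 is estimated at 18000 nM within a range from 6000 nM up to 50000 nM as the expected span.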

Compound 3, half-maximal inhibitory concentration: 13400 nM
Estimate against measurement, compound 3: 1.3-fold (0.13 log units) above; low and high end bracket the measured number.
By their numbers in this assay, from the lowest: compounds 3, 2 and 1 (each within the scatter of the next).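

Going by these compounds alone, this pair is the first in the set to isolate a single change, and in this assay hydrogen in place of hydroxy on an aromatic carbon gives a 1.1-fold lower number from compound 2 to compound 3 (0.03 log units; within the scatter). At this position of the shared core, then, losing the hydroxy group, with the one hydrogen-bond donor and one hydrogen-bond acceptor counted for it, leaves the read-out within the scatter, so the two values cannot be told apart. Nothing measured here bears on why the read-out holds across this change.

As far as these compounds go, whether another group on this aromatic carbon, such as an amine, a methoxy group or a carboxylic acid, would shift the number beyond the scatter remains open. Also open, from the compounds shown here alone, is whether hydroxy on another carbon of the same ring would give the same result.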